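Fluoro to hydroxy on the ring of compound 2

A few compounds are considered here, and "the series" means these few. Any claim that something is new, unique, unknown or untested is made for them only; others in the source may bear on it.

Values measured in a functional assay on T47D cells (Homo sapiens) for inhibition, read by CCK-8 assay, with a stated time of 72 h, tested at 1 uM; a lower number here means less inhibition of growth, a higher number more inhibition of growth at the concentration tested
Compound 1 `CN(C)C(=O)c1cc2cnc(Nc3ccc(NC(=O)C4(C(=O)Nc5ccc(F)cc5)CC4)cc3)nc2n1C1CCCC1` gives 74.7%
Compound 2 `CN(C)C(=O)c1cc2cnc(Nc3ccc(NC(=O)C4(C(=O)Nc5cccc(F)c5)CC4)cc3)nc2n1C1CCCC1` gives -3.2%

Of these two, compound 2 holds the lower number with -3.2% and shows no growth inhibition at the concentration tested. Compound 3 `CN(C)C(=O)c1cc2cnc(Nc3ccc(NC(=O)C4(C(=O)Nc5cccc(O)c5)CC4)cc3)nc2n1C1CCCC1` keeps all of compound 2 except one group, with hydroxy in place of fluoro on an aromatic carbon, meta to a large group (hydroxy in place of fluoro on an aromatic carbon).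

For the measured compounds named here, no measured step makes this exact exchange. The nearest evidence is a number 77.9 percentage points lower from compound 1 to compound 2 (beyond the scatter) and there only the place of the fluoro group on that same ring differs. That large step shows that, for this pair, the number in this assay responds strongly to a change on this ring, yet it says nothing direct about hydroxy. With so little to go on, a moderate gain is expected rather than a return to the level of compound 1. The expected change is a number 18.2 percentage points higher from compound 2 to compound 3 (beyond the scatter) and it remains uncertain. For compound 3 the estimated value is 15% (range -5% to 55%).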

Compound 3, percent growth inhibition at one concentration: 80.7%
Beside the measured number, compound 3's estimate is 65.7 percentage points below it; the measured number lies above the stated range.
By their numbers in this assay, from the lowest: compound 2; then compounds 1 and 3 (each within the scatter of the next).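

In this assay, the step of a number 83.9 percentage points higher from compound 2 to compound 3 (beyond the scatter) shows that the place on this ring held by the fluoro group of compound 2 is not closed to growth inhibition, so the earlier step of a number 77.9 percentage points lower from compound 1 to compound 2 (beyond the scatter) cannot be read as a loss that comes with any group at that place. With a number 6 percentage points higher from compound 1 to compound 3 (within the scatter), the 3-hydroxyphenyl amide and the 4-fluorophenyl amide cannot be told apart in this assay, which means that growth inhibition at this level does not depend on a fluoro group at the position it occupies in compound 1. The exchange adds one hydrogen-bond donor and one hydrogen-bond acceptor, but no measurement here links either count, or anything else, to the large step, and the reason for it stays unexplained.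

The compounds shown leave open whether this behaviour is particular to hydroxy or would extend to a methoxy or an amino group in the same place, and how a 4-hydroxyphenyl amide would compare. All three readings also come from a single tested concentration, so they leave open whether compound 1 and compound 3 would still match across a range of concentrations.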